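The source may report more compounds than this note shows. Statements on the series, on what has been measured and on what is new or still open speak of the compounds shown alone.

Measured compounds in the series:
compound 1, `CCCC1=C(N2CC2)C(=O)C(C(COC(N)=O)OC)=C(N2CC2)C1=O` — 5.07
compound 2, `CC1=C(N2CC2)C(=O)C(Cc2ccccc2)=C(N2CC2)C1=O` — 4.69
compound 3, `CC1=C(N2CC2)C(=O)C(CCCOC(N)=O)=C(N2CC2)C1=O` — 5.93

All three share one core and were run in a functional assay on L1210 cells (Mus musculus), with a stated time of 12 days; a higher number here means a more potent compound, by a factor of ten per unit of this negative logarithm, a lower number a less potent compound. Compound 1 stands second highest of the three numbers: compound 2 gives a lower value, compound 3 a higher one, and both gaps lie beyond the scatter of the method. Within the data shown here, the only single-point step available is a number 1.24 log units higher from compound 2 to compound 3 (beyond the scatter), a large gain that comes from exchanging the group on the saturated chain carbon bound to a double-bonded ring carbon; it says nothing about the alkyl group on the other side of the core.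

Compound 4, `CCC1=C(N2CC2)C(=O)C(C(COC(N)=O)OC)=C(N2CC2)C1=O`, differs from compound 1 by hydrogen in place of methyl on a saturated chain carbon, two bonds along the chain from a double-bonded ring carbon. Among the measured compounds shown here, no measured pair in this set changes that position, so no step bears on it directly, and the change itself is small in count. On that basis a step of a number 0.07 log units lower from compound 1 to compound 4 (within the scatter) is expected, that is, no movement beyond the scatter in either direction. Compound 4 is estimated at 5, within a range of 4.5 to 5.5, awaiting the number from this assay.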

Compound 4, logarithm of the reciprocal of the active concentration, log(1/C): 5.22
Compound 4: middle estimate off by 0.22 log units, on the low side; measured number inside the range.
By their numbers in this assay, from the lowest: compound 2; then compounds 1 and 4 (each within the scatter of the next); then compound 3.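

In this assay, among these compounds, cutting propyl back to ethyl on the shared core gives a number 0.15 log units higher from compound 1 to compound 4 (within the scatter), and this is the first direct reading at this place, on a saturated chain carbon, two bonds along the chain from a double-bonded ring carbon. With the other side chain held the same in both compounds, hydrogen in place of methyl at this position leaves the read-out within the scatter, so this single pair shows no dependence on the difference between propyl and ethyl. No supporting measurement bears on this pair, and the data offer no explanation for the agreement of the two numbers.

From the compounds shown here alone, it remains open whether a longer chain such as butyl or pentyl, or a hydroxyl or an amine on this same carbon, would also stay within the scatter, since the pair covers only propyl and ethyl. Among the compounds shown here, it is equally open whether the same exchange would read the same way alongside the carbamoyloxy chain of compound 3, because that chain and the one in compound 1 and compound 4 have not been compared in a pair differing in one place.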